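The source may report more compounds than this note shows. Statements on the series, on what has been measured and on what is new or still open speak of the compounds shown alone.

Working notes on the series.

Compound 1 `CCOC(=O)c1c(-c2cccc(-c3ccccc3)c2)[nH]c2cc(OC(C)C)ccc2c1=O` is the reference. In an ADME assay on HepG2 cells (Homo sapiens) for cytotoxicity, read by luminescence, with a stated time of 72 h (on this read-out higher numbers stand for an effect only at larger amounts of compound and lower numbers for an effect already at smaller amounts), compound 1 gives only a limit of the assay, > 21500 nM. Compound 2 `CCOC(=O)c1c(-c2cccc(OC)c2)[nH]c2cc(OC(C)C)ccc2c1=O` differs from compound 1 in one place: methoxy in place of phenyl on an aromatic carbon. In this assay compound 2 also returns a limit, > 21500 nM. The step that the two limits leave unreadable from compound 1 to compound 2 therefore cannot be sized; both ends sit at the limit of > 21500 nM in this assay, at which 3 of the 3 values shown sit.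

Compound 3 `CCOC(=O)c1c(-c2cccc(-c3ccccc3)c2)[nH]c2cc(Cl)c(OC)cc2c1=O` carries the same phenyl group as compound 1 on a different core; the difference between the two cores is not broken down here. In this assay compound 3 likewise gives a limit, > 21500 nM.

Compound 4 `CCOC(=O)c1c(-c2cccc(OC)c2)[nH]c2cc(Cl)c(OC)cc2c1=O` is not yet measured. It differs from compound 3 by methoxy in place of phenyl on an aromatic carbon. This is the same change as that from compound 1 to compound 2, at a place described in identical words, so it counts as the same change, now made on the core of compound 3. Going by the values given here, the one earlier instance gave a step that the two limits leave unreadable from compound 1 to compound 2, and all three measured values sit at the limit of > 21500 nM in this assay, at which 3 of the 3 values shown sit, so nothing in the data distinguishes the two ends of that step.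

In this assay the expected step is a step that the limit leaves unreadable from compound 3 to compound 4, resting on the unreadable earlier step and on the fact that every measured member of the series stands at the same limit. For compound 4 the expected value in this assay is 30000 nM, with a range from 15000 nM to 100000 nM, and the most likely outcome is another limit rather than a number. The measured value for compound 4 follows.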

Compound 4, half-maximal effective concentration: > 21500 nM
Compound 4 gave a limit, no number; the forecaster's own chance of this, stated with the estimate: 85%; the middle value is on the limit's open side.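

No new step can be read in this assay: compound 3 and compound 4 both return a limit and not a number, so the change from phenyl to methoxy has no readable size, since all the values sit at one limit: the limit of > 21500 nM in this assay, at which 4 of the 4 values shown sit.

The compounds shown leave open at what concentration any of the four would reach a half-maximal effect, and whether this change shifts that concentration on either core.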